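The source may report more compounds than this note shows. Statements on the series, on what has been measured and on what is new or still open speak of the compounds shown alone.

Measured in an ADME assay on Huh-7 cells (Homo sapiens) for cytotoxicity, with a stated time of 72 h; a lower number here means that less compound is tolerated, a higher number that more compound is tolerated:
- Compound 1 `CC(C)CCn1nc(-c2cccs2)c(O)c(C2=NS(=O)(=O)c3cc(NS(=O)(=O)C4CC4)ccc3N2)c1=O`: > 1000 nM, a limit of the assay
- Compound 2 `CC(C)CCn1nc(-c2ccccc2)c(O)c(C2=NS(=O)(=O)c3cc(NS(C)(=O)=O)ccc3N2)c1=O`: > 1000 nM, a limit of the assay

Compound 2 stands at > 1000 nM in this assay, which is a limit and not a number. The same holds across the set, which offers only (the limit of > 1000 nM in this assay, at which 2 of the 2 values shown sit). Compound 3 `CC(C)=Cc1nn(CCC(C)C)c(=O)c(C2=NS(=O)(=O)c3cc(NS(C)(=O)=O)ccc3N2)c1O` keeps the shared core and carries 2-methylprop-1-en-1-yl in place of phenyl on an aromatic carbon. Within the data shown here, no pair of measured compounds differs in one place, so the data give no measured step to judge this change by. The expectation therefore rests on the two limits alone, and no shift beyond the usual scatter is expected in this assay. The expected change is a step that the limit leaves unreadable from compound 2 to compound 3. The estimate for compound 3 is 1500 nM, with an expected range of 1000 nM to 10000 nM.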

Compound 3, half-maximal cytotoxic concentration: > 1000 nM
Compound 3 gave a limit, no number (the forecaster's own chance of this, stated with the estimate: 85%); the middle value does not contradict the limit.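

No step can be read from compound 2 to compound 3 in this assay, since neither compound gives a number, only a limit: the limit of > 1000 nM in this assay, at which 3 of the 3 values shown sit.

Still open, on these data alone, is how much of each compound the cells tolerate, and whether 2-methylprop-1-en-1-yl in place of phenyl changes that at all.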